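This account rests on a few compounds, and the source may have more. Where it says the series, first, only, none or still open, it means among the compounds named here.

Measured so far in an assay on membranes from brain for displacement of a labelled ligand from Sigma non-opioid intracellular receptor 1 (Cavia porcellus); a higher number here means a weaker inhibitor, a lower number a stronger inhibitor:
- compound 1 `COc1ccc2c(CCCCN3CCC[C@@H](C)C3)cccc2c1`, 0.24 nM
- compound 2 `COc1ccc2c(CCCCN3CCC[C@H](C)C3)cccc2c1`, 0.66 nM

Compound 2 stands highest of the two numbers in this assay; its nearest neighbour is compound 1, and the step of a 2.8-fold higher number from compound 1 to compound 2 (0.44 log units; beyond the scatter) is modest but beyond the scatter. Among the compounds with values here, the only distinction between these two is the fact that compounds 1 and 2 differ only in the configuration as drawn, so the one measured step speaks solely to the configuration of the 3-methylpiperidin-1-yl.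

Compound 3 `COc1ccc2c(CCCCN3CCC(C)(C)CC3)cccc2c1` has not yet been measured. It differs from compound 2 in this way: 4,4-dimethylpiperidin-1-yl in place of 3-methylpiperidin-1-yl on a saturated chain carbon, four bonds along the chain from an aromatic carbon. Within the data shown here, no measured step covers an exchange of the substituent pattern on the saturated six-membered ring, and the stereo step from compound 1 to compound 2 can only be taken as a sign that changes at this ring shift the number modestly. For compound 3 the step of a 1.2-fold higher number from compound 2 to compound 3 (0.08 log units; within the scatter) is therefore expected to be small, most likely within the scatter, with the direction open. In this assay compound 3 is estimated at 0.8 nM, with a range from 0.25 nM to 3 nM.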

Compound 3, inhibition constant: 2.25 nM
The estimate for compound 3 lay 2.8-fold (0.45 log units) below the measured number; low and high end bracket the measured number.
By their numbers in this assay, from the lowest: compound 1; then compound 2; then compound 3.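

In this assay, 4,4-dimethylpiperidin-1-yl in place of 3-methylpiperidin-1-yl gives a 3.4-fold higher number from compound 2 to compound 3 (0.53 log units; beyond the scatter) and a 9.4-fold higher number from compound 1 to compound 3 (0.97 log units; beyond the scatter), so compound 3 carries the highest number of the three and is the weakest inhibitor here. The earlier pair showed only what a change of configuration does at this ring; these steps show that a change of the substituent pattern on the saturated six-membered ring also moves the number beyond the scatter, in the same direction from either configuration. Nothing at hand gives a cause for these two steps.

As far as these compounds go, the two steps change the number of methyl groups and their place on the ring together, so the share of each stays open; 4-methylpiperidin-1-yl and 3,3-dimethylpiperidin-1-yl would separate them, and the unsubstituted piperidin-1-yl would show what any methyl group contributes. Also open, from the compounds shown here alone, is whether the order of these rings holds with a longer chain to the shared core, or with a morpholin-4-yl ring in place of the piperidine.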